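Sulfonyl aryl swaps in the series, toward compound 4

The source may hold more compounds than are shown below. What is called first, only, known or untested is meant among the compounds shown, and "the series" means these compounds.

The compounds share one core, seen in compound 1 `O=S(=O)(Nc1ccc(-c2nc3ccccc3o2)cc1)c1cccs1`. In an assay on cells for inhibition of HSP60/HSP10 (Homo sapiens), with a stated time of 60 min (a higher number here means a weaker inhibitor, a lower number a stronger inhibitor), compound 1 gives 63000 nM. Compound 2 `O=S(=O)(Nc1ccc(-c2nc3ccccc3o2)cc1)c1cccc(Cl)c1` gives 54000 nM in this assay, and the step of a 1.2-fold lower number from compound 1 to compound 2 (0.07 log units; within the scatter). Compound 3 `Cc1cccc(S(=O)(=O)Nc2ccc(-c3nc4ccccc4o3)cc2)c1` carries a 3-methylphenyl on the sulfonyl sulfur. In this assay compound 3 reaches only a limit, > 100000 nM, and (the limit of > 100000 nM in this assay, at which 1 of the 3 values shown sits). Into compound 3 the steps are an at least 1.5-fold higher number from compound 1 to compound 3 (0.20 log units; that floor lies within the scatter) and an at least 1.8-fold higher number from compound 2 to compound 3 (0.26 log units; that floor lies within the scatter), so compound 3 stands at the weak end of the numbers shown, but no step to it exceeds the scatter.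

Compound 4 `CCc1ccc(S(=O)(=O)Nc2ccc(-c3nc4ccccc4o3)cc2)cc1` is the next point. The change is 4-ethylphenyl in place of 3-methylphenyl on a sulfonyl sulfur. All three measured steps vary the group on the sulfonyl sulfur, and none of them moved this assay beyond the scatter. The step that the limit leaves unreadable from compound 3 to compound 4 is therefore expected to stay within the scatter, with compound 4 likely again at the limit. Compound 4 is estimated at 120000 nM, in the range 50000 nM to 300000 nM.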

Compound 4, half-maximal inhibitory concentration: > 100000 nM
Compound 4 gave a limit, no number (the forecaster's own chance of this, stated with the estimate: 65%); the middle value is on the limit's open side.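

In this assay compound 4 gives only a limit, not a number, and 4-ethylphenyl on the sulfonyl sulfur thus joins 3-methylphenyl at that limit: the limit of > 100000 nM in this assay, at which 2 of the 4 values shown sit.

The step between those two limits cannot be read, while the floors of the two readable steps, an at least 1.8-fold higher number from compound 2 to compound 4 (0.26 log units; that floor lies within the scatter) and an at least 1.5-fold higher number from compound 1 to compound 4 (0.20 log units; that floor lies within the scatter), do not separate 4-ethylphenyl from 3-chlorophenyl or thiophen-2-yl. With four groups now on the sulfonyl sulfur, no readable step at this place lies beyond the scatter.

On these data alone, whether compound 3 and compound 4 differ at all past their limits stays open. So does how an amine or a carboxylic acid on the aryl ring, or a longer chain in place of the ethyl, would read in this assay.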